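Swapping Methoxy for Dimethylamino on an Aromatic Ring

The source may hold more compounds than are shown below. What is called first, only, known or untested is meant among the compounds shown, and "the series" means these compounds.

Compound 1 `C/C(=C\c1ccccc1)C(=O)/C=C/c1ccc(N(C)C)cc1`: 20200 nM
Compound 2 `COc1ccc(/C=C/C(=O)/C(C)=C/c2ccc(N(C)C)cc2)cc1`: 34300 nM

In an ADME assay on J774.A1 cells (Mus musculus) for cytotoxicity, read by MTT assay, with a stated time of 48 h (on this read-out lower numbers stand for higher toxicity in this test and higher numbers for lower toxicity in this test), compound 2 gives 34300 nM and compound 1 gives 20200 nM, two values within the usual scatter of each other. Compound 3 `C/C(=C\c1ccc(N(C)C)cc1)C(=O)/C=C/c1ccc(N(C)C)cc1` differs from compound 2 in one place: dimethylamino in place of methoxy on an aromatic carbon. For the measured compounds named here, no measured pair shows what such a swap does, so any expectation here is loose. At most a small move towards lower numbers is expected, nothing beyond the scatter. The estimated change is a 1.4-fold lower number from compound 2 to compound 3 (0.14 log units; within the scatter). For compound 3 the expected value is 25000 nM, with an estimated range of 10000 nM to 60000 nM.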

Compound 3, half-maximal cytotoxic concentration: 10000 nM
Beside the measured number, compound 3's estimate is 2.5-fold (0.40 log units) above it; the measured number falls inside the stated range.
By their numbers in this assay, from the lowest: compound 3; then compounds 1 and 2 (each within the scatter of the next).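

In this assay, this place on the aromatic ring now shows a real response, which hydrogen and methoxy, with values within the scatter of each other, did not show. Dimethylamino in place of methoxy gives a 3.4-fold lower number from compound 2 to compound 3 (0.54 log units; beyond the scatter), and dimethylamino in place of hydrogen gives a 2.0-fold lower number from compound 1 to compound 3 (0.31 log units; beyond the scatter), both modest but beyond the scatter. No measurement here explains this shift towards higher toxicity in this test. From the compounds shown here alone, whether a primary amine or a carboxylic acid at this place would move the number the same way stays open.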